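Bromo-quinoline carboxamides: an aminoethylamino replacement at the 8-position oxygen

This account rests on a few compounds, and the source may have more. Where it says the series, first, only, none or still open, it means among the compounds named here.

Three members of the series have been run in a functional assay on MDA-MB-435 cells (Homo sapiens) for cytotoxicity, read by MTT assay, with a stated time of 72 h; on this read-out higher numbers stand for weaker inhibition and lower numbers for stronger inhibition. Compound 1 `C[C@@H](CO)Nc1nc(C(=O)NCc2ccc(F)cc2)c(O)c2ncccc12` reaches only the limit of the assay, and in this assay compound 1 gives > 20000 nM. Within the data shown here, compound 2 `N[C@H]1CC[C@H](Nc2c(C(=O)NCc3ccc(Cl)cc3)nc(Br)c3cccnc23)CC1` is the single member with a number rather than a limit; in this assay compound 2 gives 1000 nM. Compound 3 `CS(=O)(=O)Oc1c(C(=O)NCc2ccc(F)cc2)nc(Br)c2cccnc12`, with a (methylsulfonyl)oxy group on the core, again stops at the limit, and in this assay compound 3 gives > 20000 nM. Thus compound 3 sits at the limit of > 20000 nM in this assay, at which 2 of the 3 values shown sit, alongside compound 1, while compound 2 stands apart from both with a measured number.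

Compound 4 `NCCNc1c(C(=O)NCc2ccc(F)cc2)nc(Br)c2cccnc12` is not yet measured. The change from compound 3 is (2-aminoethyl)amino in place of (methylsulfonyl)oxy on an aromatic carbon. Among the measured compounds shown here, no step between measured compounds lies directly on this change, but compound 2, which also carries a bromo group and an amino-bearing amino substituent on the core, returns a number in this assay, 1000 nM. On that basis compound 4 is expected to move away from the limit, and the step of an at least 6.6-fold lower number from compound 3 to compound 4 (0.82 log units; beyond the scatter) is expected to be toward stronger inhibition, beyond the usual scatter. The estimate for compound 4 in this assay is 3000 nM, within 800 nM to 15000 nM.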

Compound 4, half-maximal inhibitory concentration: 12000 nM
Compound 4: the middle estimate sits 4.0-fold (0.60 log units) below what was measured; measured number inside the range.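

Replacing (methylsulfonyl)oxy with (2-aminoethyl)amino on this aromatic carbon, para to the bromo group, yields a measured number at this position: in this assay compound 4 gives 12000 nM. The change gives an at least 1.6-fold lower number from compound 3 to compound 4 (0.22 log units; that floor lies within the scatter), so the data support a lower number only as an open-ended step, and its floor alone does not establish a difference beyond the scatter. The value of compound 3 is a limit and not a number, which leaves the true size of the step unknown: the limit of > 20000 nM in this assay, at which 2 of the 4 values shown sit.

From the compounds shown here alone, it remains open whether the value of compound 4 depends on the terminal amine of the (2-aminoethyl)amino group or on the chain as a whole, a question that a 2-hydroxyethylamino group, a plain amino group or a longer 3-aminopropylamino chain at the same position could address. Compound 2 also carries an amino-bearing substituent but differs from compound 4 in more than one place, so the compounds shown do not say how the cyclic diamine and the chain compare when all else is held constant.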